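Trimming the Amide Nitrogen Substituent Back to a Small Group

A few compounds are considered here, and "the series" means these few. Any claim that something is new, unique, unknown or untested is made for them only; others in the source may bear on it.

Of the compounds shown here, three so far share one core and differ only in the group carried on an amide-type nitrogen. Compound 1 `CCCCNC(=O)[C@H]1OC(n2cnc3c(N)ncnc32)[C@H](O)[C@@H]1O` gives 17 nM in an assay on cell membranes for binding affinity to 2-oxoglutarate receptor 1 (Rattus norvegicus), read by radioligand binding; on this read-out lower numbers stand for stronger inhibition and higher numbers for weaker inhibition. Compound 2 `CC(=O)NCCNC(=O)[C@H]1OC(n2cnc3c(N)ncnc32)[C@H](O)[C@@H]1O` gives 46 nM in this assay, a change described by a 2.7-fold higher number from compound 1 to compound 2 (0.43 log units; beyond the scatter). Compound 3 `Nc1ncnc2c1ncn2C1O[C@H](C(=O)NC2CC3CCC2C3)[C@@H](O)[C@H]1O` gives 640 nM in this assay, the highest number of the three and therefore the weakest binder, with a 38-fold higher number from compound 1 to compound 3 (1.58 log units; beyond the scatter) and a 14-fold higher number from compound 2 to compound 3 (1.14 log units; beyond the scatter) marking the steps that lead to it.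

Compound 4 `CCONC(=O)[C@H]1OC(n2cnc3c(N)ncnc32)[C@H](O)[C@@H]1O` differs from compound 3 by a group of 3 heavy atoms (2 carbon, 1 oxygen; no ring) in place of a group of 7 heavy atoms (7 carbon; 2 five-membered non-aromatic rings of carbon only), on an amide-type nitrogen. Both measured steps toward compound 3 bear on this change: each time the group on the amide-type nitrogen grew into the two-ring group of 7 heavy atoms, the number rose by a large step. Going back to a small group is therefore expected to lower the number by a large step, although no measured compound carries a group joined through oxygen on this nitrogen, so the range stays wide. For compound 4 the expected value is 60 nM, with a range from 15 nM to 250 nM. The expected step is an 11-fold lower number from compound 3 to compound 4 (1.03 log units; beyond the scatter).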

Compound 4, inhibition constant: 67 nM
Compound 4: the middle estimate sits 1.1-fold (0.05 log units) below what was measured; measured number inside the range.
By their numbers in this assay, from the lowest: compound 1; then compounds 2 and 4 (each within the scatter of the next); then compound 3.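

The large loss seen with the two-ring group is not a fixed feature of this amide-type nitrogen: ethoxy in its place gives a 9.6-fold lower number from compound 3 to compound 4 (0.98 log units; beyond the scatter) in this assay and brings the number back toward those of the open-chain groups. Ethoxy and 2-acetamidoethyl cannot be told apart, with a 1.5-fold higher number from compound 2 to compound 4 (0.16 log units; within the scatter) lying within the scatter, so a group joined through oxygen is tolerated here about as well as that much larger chain, while replacing butyl with ethoxy gives a 3.9-fold higher number from compound 1 to compound 4 (0.60 log units; beyond the scatter) and leaves compound 1 the strongest binder of the four. No supporting measurement is available to explain any of these differences.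

Ethoxy and butyl differ both in the oxygen link and in chain length, so the compounds shown cannot say which of the two matters; a propyl group or a butoxy group on this nitrogen would help to separate them. Going by these compounds, it also remains open whether a single small ring, such as cyclopropyl, would behave like the open chains or like the two-ring group.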